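Swapping a five-membered ring at the amide in compound 1

The compounds below may be only part of what the source reports. "The series", "measured", "known", "first", "only" and "open" are said of these compounds alone.

Of the compounds shown here, three sharing one core have been measured in a functional assay on SK-BR-3 cells (Homo sapiens) for antiproliferative activity, read by MTT assay, with a stated time of 72 h; a higher number here means a weaker inhibitor, a lower number a stronger inhibitor. Compound 1 `CCN1CCN(c2cc(C)c3cc(NC(=O)c4ccc[nH]4)ccc3n2)CC1` gives 13200 nM. Compound 2 `CCN1CCN(c2cc(C)c3cc(NC(=O)c4ccc5ccccc5n4)ccc3n2)CC1`, which carries quinolin-2-yl on the carbonyl carbon, gives 3760 nM, and compound 3 `CCN1CCN(c2cc(C)c3cc(NC(=O)c4cccc(Br)c4)ccc3n2)CC1`, with 3-bromophenyl there, gives 13300 nM. Among these numbers compound 1 stands second highest: its value and that of compound 3 lie within the usual scatter of each other, so the two cannot be told apart, while compound 2 sits clearly lower, as the step of a 3.5-fold lower number from compound 1 to compound 2 (0.55 log units; beyond the scatter) shows.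

Compound 4 `CCN1CCN(c2cc(C)c3cc(NC(=O)c4ccco4)ccc3n2)CC1` differs from compound 1 at a single place: furan-2-yl in place of 1H-pyrrol-2-yl on a carbonyl carbon. Among the compounds with values here, no measured step exchanges one five-membered ring for another; the two steps that start from compound 1 replace the 1H-pyrrol-2-yl with much larger groups. One of them, a 3.5-fold lower number from compound 1 to compound 2 (0.55 log units; beyond the scatter), is modest; the other, a 1.0-fold higher number from compound 1 to compound 3 (0.00 log units; within the scatter), stays within the scatter. A change as small as the present one gives no ground to expect more than scatter-level movement in this assay . The number for compound 4 is therefore expected to sit close to that of compound 1, with the step of a 1.1-fold higher number from compound 1 to compound 4 (0.06 log units; within the scatter) estimated to lie within the usual scatter. The estimate for compound 4 is 15000 nM, with a range from 6000 nM to 40000 nM.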

Compound 4, half-maximal inhibitory concentration: 37500 nM
Estimate against measurement, compound 4: 2.5-fold (0.40 log units) below, within the range that was stated.
By their numbers in this assay, from the lowest: compound 2; then compounds 1 and 3 (each within the scatter of the next); then compound 4.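

Replacing 1H-pyrrol-2-yl with furan-2-yl keeps a five-membered aromatic ring on the carbonyl carbon, yet this assay shows a 2.8-fold higher number from compound 1 to compound 4 (0.45 log units; beyond the scatter). A hydrogen-bond donor gives way to a hydrogen-bond acceptor in this exchange, so this position can respond to a change in the ring's hetero atom, even though the much larger 3-bromophenyl could not be told apart from 1H-pyrrol-2-yl. Compound 4 is also the weakest of the four, with a 2.8-fold higher number from compound 3 to compound 4 (0.45 log units; beyond the scatter) and a 10-fold higher number from compound 2 to compound 4 (1.00 log units; beyond the scatter), but no measurement shown here explains why the number rises.

The compounds shown cannot separate the loss of the donor from the gain of the acceptor, and thiophen-2-yl or 1-methyl-1H-pyrrol-2-yl at this place would give further five-membered rings to set against compound 1 and compound 4. Also open, on these data alone, is whether the lower number seen with quinolin-2-yl extends to other fused rings, such as indol-2-yl.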